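The source may report more compounds than this note shows. Statements on the series, on what has been measured and on what is new or still open speak of the compounds shown alone.

Compound 1 `O=C(Nc1ccc(O)c(-c2nc3ccccc3s2)c1)c1cc([N+](=O)[O-])ccc1Cl`: > 25000 nM
Compound 2 `O=C(Nc1ccc(Cl)c(-c2nc3ccccc3s2)c1)c1cc([N+](=O)[O-])ccc1Cl`: > 25000 nM

In an ADME assay on HEK293 cells (Homo sapiens) for cytotoxicity, with a stated time of 72 h (a lower number here means that less compound is needed, a higher number that more compound is needed for the effect), compound 1 gives only a limit, > 25000 nM. Compound 2 gives only a limit in this assay, > 25000 nM. The step that the two limits leave unreadable from compound 1 to compound 2 is thus not readable. Compound 2 stands at the limit; (the limit of > 25000 nM in this assay, at which 2 of the 2 values shown sit).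

Compound 3 `O=C(Nc1ccc(Cl)c(C(F)(F)F)c1)c1cc([N+](=O)[O-])ccc1Cl` differs from compound 2 by trifluoromethyl in place of 1,3-benzothiazol-2-yl on an aromatic carbon. No readable measured step bears on this change. With nothing to set a direction, no step beyond the scatter is assumed, and compound 3 is expected to stay at the limit in this assay, estimated at 35000 nM (range 12000 nM to 100000 nM), which means an expected step that the limit leaves unreadable from compound 2 to compound 3.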

Compound 3, half-maximal effective concentration: > 27000 nM
Compound 3: only a limit was reported (the forecaster's own chance of this, stated with the estimate: 80%); the middle value is on the limit's open side.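

In this assay compound 2 and compound 3 each give only a limit, so no step can be read between them. The compounds shown leave open whether trifluoromethyl in place of 1,3-benzothiazol-2-yl changes the half-maximal effective concentration at all.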